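Pyridin-3-yl in place of 4-fluorophenyl: compound 4

The source may hold more compounds than are shown below. What is called first, only, known or untested is meant among the compounds shown, and "the series" means these compounds.

Measured so far in an assay on membranes from brain for binding affinity to Neuronal acetylcholine receptor; alpha4/beta2 (Rattus norvegicus); a higher number here means a weaker inhibitor, a lower number a stronger inhibitor:
compound 1 `COc1ccc(-c2cncc(OC[C@@H]3CCCN3C)c2)cc1` gives 0.32 nM
compound 2 `CN1CCC[C@H]1COc1cncc(-c2ccc(F)cc2)c1` gives 0.11 nM
compound 3 `CN1CCC[C@H]1COc1cncc(-c2ccc(F)c(Cl)c2)c1` gives 0.055 nM

Compound 2 sits second highest of the three numbers; from compound 1 the step was a 2.9-fold lower number from compound 1 to compound 2 (0.46 log units; beyond the scatter), and from compound 2 onward a 2.0-fold lower number from compound 2 to compound 3 (0.30 log units; within the scatter).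

Compound 4 `CN1CCC[C@H]1COc1cncc(-c2cccnc2)c1` differs from compound 2 by pyridin-3-yl in place of 4-fluorophenyl on an aromatic carbon. Neither measured step bears directly on this change: both concern substituents on the ring that leaves, not its replacement by a ring with a nitrogen. The series therefore gives no direct guide; a modest drift toward a higher number in this assay is expected, the step of a 2.7-fold higher number from compound 2 to compound 4 (0.44 log units; beyond the scatter) plausibly near the edge of scatter. Compound 4 is estimated at 0.3 nM, range 0.08 nM to 1.2 nM.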

Compound 4, inhibition constant: 0.27 nM
The estimate for compound 4 lay 1.1-fold (0.05 log units) above the measured number; low and high end bracket the measured number.
By their numbers in this assay, from the lowest: compounds 3 and 2 (each within the scatter of the next); then compounds 4 and 1 (each within the scatter of the next).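

With pyridin-3-yl in place of 4-fluorophenyl, this assay shows a 2.5-fold higher number from compound 2 to compound 4 (0.39 log units; beyond the scatter), a modest step. The earlier steps shown here changed only substituents on the phenyl ring, whereas this one shows that the ring itself can be exchanged for one carrying a nitrogen and a hydrogen-bond acceptor, with compound 4 still at 0.27 nM. No measurement at hand accounts for the size of this step.

Open, on these data alone, is how pyridin-4-yl would read at this position in this assay, and whether an amine or a carboxylic acid on the ring would be tolerated.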